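This account rests on a few compounds, and the source may have more. Where it says the series, first, only, none or still open, it means among the compounds named here.

Of the compounds shown here, three that share one core have been measured in an assay on BaF3 cells for inhibition of proto-oncogene tyrosine-protein kinase receptor Ret (Homo sapiens), read by MTT assay, with a stated time of 48 h; on this read-out lower numbers stand for stronger inhibition of growth and higher numbers for weaker inhibition of growth. Compound 1 `CC(C)n1nc(-c2ccon2)c2c(N)ncnc21` carries hydrogen on an aromatic carbon of its five-membered ring, and in this assay compound 1 gives 3210 nM. Compound 2 `CC(C)n1nc(-c2cc(C(C)(C)C)on2)c2c(N)ncnc21` carries tert-butyl on that aromatic carbon, and in this assay compound 2 gives 6120 nM. Compound 3 `CC(C)n1nc(-c2cc(-c3ccccc3)on2)c2c(N)ncnc21` carries phenyl there, and in this assay compound 3 gives 3460 nM, the second highest of the three numbers, with compound 1 nearest and compound 2 furthest.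

Compound 4 `CC(C)c1cc(-c2nn(C(C)C)c3ncnc(N)c23)no1` has not yet been measured. It differs from compound 3 by isopropyl in place of phenyl on an aromatic carbon. For the measured compounds named here, three steps bear on this change: a 1.9-fold higher number from compound 1 to compound 2 (0.28 log units; within the scatter), a 1.1-fold higher number from compound 1 to compound 3 (0.03 log units; within the scatter) and a 1.8-fold lower number from compound 2 to compound 3 (0.25 log units; within the scatter), and all of them stay within the scatter. Hydrogen, tert-butyl and phenyl on that aromatic carbon thus give numbers that cannot be told apart, and no step beyond the scatter is expected when isopropyl takes the place of phenyl. The expected step is a 1.3-fold higher number from compound 3 to compound 4 (0.11 log units; within the scatter). For compound 4 the estimate in this assay is 4500 nM, within a range from 2000 nM to 10000 nM.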

Compound 4, concentration for 50% growth inhibition: 2400 nM
The estimate for compound 4 lay 1.9-fold (0.27 log units) above the measured number, and the stated range covers the measured number.
By their numbers in this assay, from the lowest: compounds 4, 1, 3 and 2 (each within the scatter of the next, the first and the last beyond it).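

For the compounds shown here, this is the first change at this position that reaches beyond the scatter: in this assay, taking one methyl off tert-butyl to leave isopropyl gives a 2.6-fold lower number from compound 2 to compound 4 (0.41 log units; beyond the scatter) and shows that this aromatic carbon does respond to the group it carries. The response is modest and narrow, as the steps of a 1.4-fold lower number from compound 3 to compound 4 (0.16 log units; within the scatter) and a 1.3-fold lower number from compound 1 to compound 4 (0.13 log units; within the scatter) stay within the scatter. Isopropyl therefore cannot be told apart from phenyl or hydrogen here, and only tert-butyl and isopropyl separate, with hydrogen and phenyl each within the scatter of both.

On these data alone, whether an amine, a carboxylic acid or a longer chain on this carbon would move the number further in either direction stays open, as does whether the gap between tert-butyl and isopropyl would hold up on repeated measurement. Nothing measured here gives a reason for that gap.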